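Moving One Hydroxyl: From Compound 2 to Compound 3

The source may hold more compounds than are shown below. What is called first, only, known or untested is meant among the compounds shown, and "the series" means these compounds.

Measured compounds:
Compound 1: `Oc1cccc(-c2cc(-c3ccccc3O)cc(-c3ccccc3O)n2)c1` — 0%
Compound 2: `Oc1ccc(-c2cc(-c3ccccc3O)nc(-c3ccccc3O)c2)cc1` — 3.7%

In an assay on isolated protein for inhibition of DNA topoisomerase 1 (Homo sapiens), with a stated time of 30 min, tested at 100 uM (on this read-out lower numbers stand for less inhibition and higher numbers for more inhibition at the one concentration tested (going by the name of the read-out)), compound 1 gives 0%. In this assay compound 2 gives 3.7%, the higher of the two numbers, but the gap to compound 1 lies within the scatter, so the two compounds cannot be told apart on this read-out; both show essentially no inhibition at the concentration tested.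

Compound 3, `Oc1ccc(-c2cc(-c3cccc(O)c3)nc(-c3ccccc3O)c2)cc1`, is the next compound. It differs from compound 2 in one place: 3-hydroxyphenyl in place of 2-hydroxyphenyl on an aromatic carbon. Going by the values given here, no step between two measured compounds is available that would show what such a rearrangement does in this assay.

With both measured values near the bottom of the scale and within the scatter of each other, the expected step from compound 2 to compound 3 in this assay is a number 0.3 percentage points higher from compound 2 to compound 3 (within the scatter), that is, none beyond the scatter. Compound 3 is therefore estimated at 4%, within a range from 0% to 15%.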

Compound 3, a percentage reported as inhibition, at one concentration (the size of the read-out at that concentration, not a potency): 1.5%
Estimate against measurement, compound 3: 2.5 percentage points above, within the range that was stated.
By their numbers in this assay, from the lowest: compounds 1, 3 and 2 (each within the scatter of the next).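

In this assay, the first step read at this position, 3-hydroxyphenyl in place of 2-hydroxyphenyl on the aromatic carbon next to the ring nitrogen, comes to a number 2.2 percentage points lower from compound 2 to compound 3 (within the scatter), so this rearrangement of the hydroxyl group leaves compound 2 and compound 3 indistinguishable on this read-out. The second new step, again a swap of one hydroxyphenyl group for another, comes to a number 1.5 percentage points higher from compound 1 to compound 3 (within the scatter), so that change cannot be told from no change either, and the two steps together show that neither swap lifts the number clear of the scatter. No independent observation is available to explain this flat result.

All three compounds carry only hydroxyphenyl groups on the shared core and all sit near the bottom of the scale, so these steps say little about how the position would respond to a larger difference in the substituent. Whether an amine, a carboxylic acid or a methoxy group on these rings would give a number beyond the scatter remains open, as does what any of these compounds would do at another concentration.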